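A few compounds are considered here, and "the series" means these few. Any claim that something is new, unique, unknown or untested is made for them only; others in the source may bear on it.

In a functional assay on RAW264.7 cells (Mus musculus) for inhibition, read by Griess assay, with stated times of 2 h and 24 h (on this read-out higher numbers stand for weaker inhibition and lower numbers for stronger inhibition), compound 3 `COc1ccc([C@@H]2C/C(=N\O)c3c(O)cc(OCc4cn(Cc5ccccc5F)nn4)cc3O2)cc1O` gives 5710 nM, the second highest of the three numbers. Compound 1 `CCn1cc(COc2cc(O)c3c(c2)O[C@H](c2ccc(OC)c(O)c2)C/C3=N\O)nn1` gives 3140 nM; compound 2 `COc1ccc([C@@H]2CC(=O)c3c(O)cc(OCc4cn(Cc5ccccc5C(F)(F)F)nn4)cc3O2)cc1O` gives 12500 nM. Compound 3 and compound 2 differ in two places, so their values are set side by side without a computed step. Compound 4 `COc1ccc([C@@H]2C/C(=N\O)c3c(O)cc(OCc4cn(-c5ccccc5)nn4)cc3O2)cc1O` carries phenyl in place of 2-fluorobenzyl on an aromatic nitrogen. Among the measured compounds shown here, the only measured step that alters this part of the series, a 1.8-fold higher number from compound 1 to compound 3 (0.26 log units; within the scatter), lay within the scatter, and it is the sole guide here. No step beyond the scatter is therefore expected in this assay for compound 4, so a 1.0-fold lower number from compound 3 to compound 4 (0.02 log units; within the scatter) is the estimated step. Compound 4 is expected at 5500 nM, with a range from 2200 nM to 14000 nM.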

Compound 4, half-maximal inhibitory concentration: 6130 nM
Compound 4: the middle estimate sits 1.1-fold (0.05 log units) below what was measured; low and high end bracket the measured number.
By their numbers in this assay, from the lowest: compounds 1, 3 and 4 (each within the scatter of the next); then compound 2.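

In this assay, the aromatic nitrogen of the five-membered ring takes phenyl in place of 2-fluorobenzyl (a 1.1-fold higher number from compound 3 to compound 4 (0.03 log units; within the scatter)) and phenyl in place of ethyl (a 2.0-fold higher number from compound 1 to compound 4 (0.29 log units; within the scatter)). A phenyl bound directly to that nitrogen thus gives no step beyond the scatter, so ethyl, 2-fluorobenzyl and phenyl are not told apart at this position. No evidence on hand accounts for this. Open, from the compounds shown here alone, is whether an amine or a carboxylic acid on that nitrogen's substituent would also stay within the scatter.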